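Swapping the hydroxyl for a methyl ether on the side chain

The compounds below may be only part of what the source reports. "The series", "measured", "known", "first", "only" and "open" are said of these compounds alone.

Compound 1, `Cn1ncc(Cl)c1-c1cc(C(=O)N[C@@H]2CN[C@H](CCCO)C[C@H]2c2ccc(Cl)c(Cl)c2)oc1Cl`, gives 600 nM in a functional assay on OVCAR-8 cells (Homo sapiens) for antiproliferative activity (on this read-out lower numbers stand for stronger inhibition and higher numbers for weaker inhibition), the lowest of the three numbers measured. Compound 2, `CCC[C@@H]1C[C@@H](c2ccc(Cl)c(Cl)c2)[C@H](NC(=O)c2cc(-c3c(Cl)cnn3C)c(Cl)o2)CN1`, gives 1620 nM, and compound 3, `Cn1ncc(Cl)c1-c1cc(C(=O)N[C@@H]2CN[C@H](CCN3CCCC3)C[C@H]2c2ccc(Cl)c(Cl)c2)oc1Cl`, gives 1840 nM; both steps, a 2.7-fold higher number from compound 1 to compound 2 (0.43 log units; beyond the scatter) and a 3.1-fold higher number from compound 1 to compound 3 (0.49 log units; beyond the scatter), are beyond the scatter, so compound 1 is the most potent of the three. Compound 2 and compound 3 sit within the scatter of each other, a 1.1-fold higher number from compound 2 to compound 3 (0.06 log units; within the scatter).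

Compound 4, `COCC[C@@H]1C[C@@H](c2ccc(Cl)c(Cl)c2)[C@H](NC(=O)c2cc(-c3c(Cl)cnn3C)c(Cl)o2)CN1`, differs from compound 1 in one place: methoxy in place of hydroxymethyl on a saturated chain carbon, two bonds along the chain from a saturated ring carbon. The hydroxymethyl that leaves carries a hydrogen-bond donor; the methoxy that enters does not. Both measured steps away from compound 1 removed that same hydroxy group and both cost potency by a modest margin, a 2.7-fold higher number from compound 1 to compound 2 (0.43 log units; beyond the scatter) and a 3.1-fold higher number from compound 1 to compound 3 (0.49 log units; beyond the scatter). Compound 4 is therefore expected to lose potency against compound 1 by a similar modest step, a 2.3-fold higher number from compound 1 to compound 4 (0.37 log units; beyond the scatter), because the change again removes the hydroxy donor as in a 2.7-fold higher number from compound 1 to compound 2 (0.43 log units; beyond the scatter). Compound 4 is estimated at 1400 nM, within a range from 600 nM to 3500 nM.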

Compound 4, half-maximal inhibitory concentration: 1060 nM
Compound 4: middle estimate off by 1.3-fold (0.12 log units), on the high side; measured number inside the range.
By their numbers in this assay, from the lowest: compounds 1, 4, 2 and 3 (each within the scatter of the next, the first and the last beyond it).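

In this assay, moving from hydroxymethyl to methoxy on this side chain, with the same atoms joined differently and the hydrogen-bond donor gone, gives a 1.8-fold higher number from compound 1 to compound 4 (0.25 log units; within the scatter), so at this position the loss of that donor is not by itself shown to separate two compounds. Compound 4 is also within the scatter of the methyl and pyrrolidin-1-yl compounds, at a 1.5-fold lower number from compound 2 to compound 4 (0.18 log units; within the scatter) and a 1.7-fold lower number from compound 3 to compound 4 (0.24 log units; within the scatter), so it can be placed with neither end of the set, even though compound 1 stands beyond the scatter from compound 2 and compound 3. Nothing available explains these numbers or links them to any property of the groups.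

The compounds shown leave open how a carboxylic acid or a primary amine would read at the end of this chain. They also leave open whether a longer chain ending in hydroxy would hold the number of compound 1.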